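Replacing iodine with hydrogen on a saturated lactone core

This account rests on a few compounds, and the source may have more. Where it says the series, first, only, none or still open, it means among the compounds named here.

Of the compounds shown here, three have been measured so far in a functional assay on ZR-75-1 cells (Homo sapiens) for cytotoxicity; on this read-out higher numbers stand for an effect only at larger amounts of compound and lower numbers for an effect already at smaller amounts. Compound 1, `CCC[C@@H](OC(C)=O)C1=C(Br)/C(=C/Br)OC1=O`, gives 1.6 ug/mL in this assay. Compound 2, `CCC[C@@H](O)C1=C(Br)/C(=C/I)OC1=O`, gives 0.3 ug/mL. Compound 3, `CCC[C@@H](OC(C)=O)C1=C(Br)[C@@](CI)(OC)OC1=O`, gives 7.9 ug/mL, the highest number of the three, meaning its effect appears only at a larger amount of compound than for compound 1 or compound 2; both gaps are beyond the usual scatter.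

Compound 4, `CCC[C@@H](OC(C)=O)C1=C(Br)[C@@](C)(OC)OC1=O`, has not been measured yet. It differs from compound 3 in one place: hydrogen in place of iodo on a saturated chain carbon bound to a saturated ring carbon. Among the measured compounds shown here, with no measured pair showing this same change, there is no direct guide to the size of the step. Compound 3 already stands at the high end, and the expectation for compound 4 is a modest further rise, as a step of a 1.5-fold higher number from compound 3 to compound 4 (0.18 log units; within the scatter). In this assay compound 4 is estimated to give 12 ug/mL, with a plausible range from 4 ug/mL to 40 ug/mL.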

Compound 4, concentration for half-maximal effect: 2.4 ug/mL
Estimate against measurement, compound 4: 5.0-fold (0.70 log units) above, and the stated range ends above it.
By their numbers in this assay, from the lowest: compound 2; then compounds 1 and 4 (each within the scatter of the next); then compound 3.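

In this assay, the iodine on this chain carbon proves not to be needed for the effect: hydrogen in place of iodo on a saturated chain carbon bound to a saturated ring carbon gives a 3.3-fold lower number from compound 3 to compound 4 (0.52 log units; beyond the scatter), so the effect now appears at a smaller amount of compound. This is the only pair shown that differs in one place, and so the only direct reading of a single change in this set. Nothing available explains why the number falls with this change.

Going by these compounds, it stays open whether a bromomethyl, hydroxymethyl or aminomethyl group in this place would sit nearer compound 3 or nearer compound 4. One pair also cannot say whether iodomethyl to methyl would give a similar step with a free hydroxyl group in place of the acetate ester.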